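Ester variation on a shared core: cytotoxicity working notes

The compounds below may be only part of what the source reports. "The series", "measured", "known", "first", "only" and "open" are said of these compounds alone.

The compounds share one core and differ only in the ester on its side chain. Compound 1 `CC(=O)OCCc1c(-c2ccccc2Cl)c2cc(Cl)ccc2[nH]c1=O` carries the smallest ester; in an ADME assay on HepG2 2.2.15 cells (Homo sapiens) for cytotoxicity (on this read-out lower numbers stand for higher toxicity in this test and higher numbers for lower toxicity in this test), compound 1 gives 27000 nM. Compound 2 `CCCCC(=O)OCCc1c(-c2ccccc2Cl)c2cc(Cl)ccc2[nH]c1=O` gives 200000 nM in this assay, and compound 3 `O=C(OCCc1c(-c2ccccc2Cl)c2cc(Cl)ccc2[nH]c1=O)C1CCCC1` gives 46000 nM in this assay. Compound 3 therefore stands second highest of the three numbers, within the scatter of compound 1 and separated from compound 2 by a gap beyond it. The steps at the carbonyl carbon are a 1.7-fold higher number from compound 1 to compound 3 (0.23 log units; within the scatter) and a 4.3-fold lower number from compound 2 to compound 3 (0.64 log units; beyond the scatter); the step on the chain carbon is a 7.4-fold higher number from compound 1 to compound 2 (0.87 log units; beyond the scatter).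

Compound 4 `COc1ccc(/C=C/C(=O)OCCc2c(-c3ccccc3Cl)c3cc(Cl)ccc3[nH]c2=O)cc1OC` is not yet measured. Its change from compound 3 is 2-(3,4-dimethoxyphenyl)ethenyl in place of cyclopentyl on a carbonyl carbon. The two steps at the carbonyl carbon are the ones that bear on it: one within the scatter, one modest and beyond it. No measured ester carries an aromatic ring or a double bond outside aromatic rings, so the direction is open. A step within the scatter, leaning slightly towards a higher number, is expected, a 1.3-fold higher number from compound 3 to compound 4 (0.12 log units; within the scatter), because compound 2 with the largest ester gives 200000 nM. The estimate for compound 4 in this assay is 60000 nM, within 20000 nM to 200000 nM.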

Compound 4, half-maximal cytotoxic concentration: > 1200000 nM
Compound 4 gave a limit, no number; the forecaster's own chance of this, stated with the estimate: 10%; at least 20-fold (1.30 log units) between middle value and limit.
By their numbers in this assay, from the lowest: compounds 1 and 3 (each within the scatter of the next); then compound 2. At a limit, above all of these: compound 4.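

For compound 4 the read-out in this assay is a limit and not a number: the limit of > 1200000 nM in this assay, at which 1 of the 4 values shown sits.

At the carbonyl carbon, 2-(3,4-dimethoxyphenyl)ethenyl gives an at least 26-fold higher number from compound 3 to compound 4 (1.41 log units; beyond the scatter) in place of cyclopentyl, an at least 44-fold higher number from compound 1 to compound 4 (1.64 log units; beyond the scatter) in place of methyl, and an at least 6.0-fold higher number from compound 2 to compound 4 (0.77 log units; beyond the scatter) in place of butyl. The three saturated esters alone did not show that this position can move the read-out past the number of compound 2, and all three new steps lie beyond the scatter, with the group that brings an aromatic ring, a double bond and two hydrogen-bond acceptors ending highest in the series.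

Among the compounds shown here, the limit leaves the full size of these steps open, and the single change brings in the ring, the double bond and both methoxy groups together, so the shift cannot be assigned to any one of them. Whether an unsubstituted phenyl, a saturated ethyl link in place of the ethenyl, or an amine on the ester would read the same way remains open in the compounds shown.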